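This account rests on a few compounds, and the source may have more. Where it says the series, first, only, none or still open, it means among the compounds named here.

Of the compounds shown here, two so far define the series in a functional assay on V79 cells (Cricetulus griseus) for cytotoxicity, read by colony formation; a lower number here means a stronger inhibitor, a higher number a weaker inhibitor. Compound 1 (`O=C(O)c1cn(C2CC2)c2cc(N3CCCC3)c(F)cc2c1=O`) gives 38 ug/mL, and compound 2 (`CCNCC1CCN(c2nc3c(cc2F)c(=O)c(C(=O)O)cn3C2CC2)C1`) gives 160 ug/mL, the higher of the two numbers and beyond the scatter from compound 1. Among the compounds with values here, no measured step between compounds differing in one place exists yet. Compound 3 (`CC1CN(c2nc3c(cc2F)c(=O)c(C(=O)O)cn3C2CC2)CC(C)N1`) keeps the core of compound 2 and changes one substituent: 3,5-dimethylpiperazin-1-yl in place of 3-((ethylamino)methyl)pyrrolidin-1-yl on an aromatic carbon. The change sits on an aromatic carbon, ortho to a fluoro group. The expectation therefore rests only on the span from compound 1 at 38 ug/mL to compound 2 at 160 ug/mL, and the middle of the expectation for compound 3 lies inside that span, toward its upper end. The expected step, a 1.6-fold lower number from compound 2 to compound 3 (0.20 log units; within the scatter), goes toward a lower number and is estimated to stay within the scatter. For compound 3 the estimated value is 100 ug/mL, with an expected range of 40 ug/mL to 260 ug/mL.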

Compound 3, half-maximal inhibitory concentration: 250 ug/mL
Beside the measured number, compound 3's estimate is 2.5-fold (0.40 log units) below it; measured number inside the range.
By their numbers in this assay, from the lowest: compound 1; then compounds 2 and 3 (each within the scatter of the next).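

In this assay, within the data shown here, the first single-place step at this position, an aromatic carbon next to the ring nitrogen and ortho to a fluoro group, is a 1.6-fold higher number from compound 2 to compound 3 (0.19 log units; within the scatter), for 3,5-dimethylpiperazin-1-yl in place of 3-((ethylamino)methyl)pyrrolidin-1-yl. For this pair, exchanging a five-membered non-aromatic ring with 1 hetero atom for a six-membered one with 2 hetero atoms leaves the reading within the scatter, so this change at this position shows no clear effect on cytotoxicity. No measurement at hand explains this outcome.

Open, going by these compounds, is how a morpholin-4-yl ring or an unsubstituted piperazin-1-yl ring would read on the same carbon, which would also test whether the two methyl groups matter. Also open, on these data alone, is whether the same exchange on the core of compound 1 gives a step of similar size.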